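From compound 2 to compound 4

The source may report more compounds than this note shows. Statements on the series, on what has been measured and on what is new or still open speak of the compounds shown alone.

Three compounds have values in an ADME assay for permeability, using PAMPA, with a stated time of 4 h, at pH 7.4 (a lower number here means that the compound crosses the layer more slowly, a higher number that the compound crosses the layer faster), so far:
Compound 1 `C/C(=C/CN(C[C@H]1Cc2ccccc2CN1)[C@H]1CCCc2cccnc21)CN` gives 11 nm/s 
Compound 2 `N[C@H]1CC[C@H](CN(C[C@H]2Cc3ccccc3CN2)[C@H]2CCCc3cccnc32)CC1` gives 12 nm/s 
Compound 3 `C/C(CN(C[C@H]1Cc2ccccc2CN1)[C@H]1CCCc2cccnc21)=C(/F)CN` gives 700 nm/s 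

Compound 2 sits level with compound 1 (a 1.1-fold higher number from compound 1 to compound 2 (0.04 log units; within the scatter)) and far short of compound 3 (a 58-fold higher number from compound 2 to compound 3 (1.77 log units; beyond the scatter)). Compound 4 `C/C(CN)=C(\F)CN(C[C@H]1Cc2ccccc2CN1)[C@H]1CCCc2cccnc21` carries 2-(aminomethyl)-1-fluoroprop-1-en-1-yl in place of 4-aminocyclohexyl, on a saturated chain carbon bound to an amine nitrogen (2-(aminomethyl)-1-fluoroprop-1-en-1-yl in place of 4-aminocyclohexyl on a saturated chain carbon bound to an amine nitrogen). The closest evidence is the large step to compound 3 (a 64-fold higher number from compound 1 to compound 3 (1.80 log units; beyond the scatter)), yet compound 3 carries a different group, 3-amino-2-fluoro-1-methylprop-1-en-1-yl. Only part of that rise is therefore expected to carry over, so the expected step is a moderate rise (a 3.3-fold higher number from compound 2 to compound 4 (0.52 log units; beyond the scatter)). The estimate for compound 4 is 40 nm/s (expected range 10 nm/s to 200 nm/s).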

Compound 4, apparent permeability: 490 nm/s
For compound 4 the middle estimate is 12-fold (1.09 log units) below the measured one, and the stated range ends below it.
By their numbers in this assay, from the lowest: compounds 1 and 2 (each within the scatter of the next); then compounds 4 and 3 (each within the scatter of the next).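

In this assay, the 2-(aminomethyl)-1-fluoroprop-1-en-1-yl group gives a large rise over the ring-bearing group (a 41-fold higher number from compound 2 to compound 4 (1.61 log units; beyond the scatter)) and over the fluorine-free open chain (a 45-fold higher number from compound 1 to compound 4 (1.65 log units; beyond the scatter)). The large rise is thus not unique to compound 3: the two fluorine-bearing groups cannot be told apart here (a 1.4-fold lower number from compound 3 to compound 4 (0.15 log units; within the scatter)). The data shown offer no measurement that explains the rise. Still open, as far as these compounds go, is whether a chlorine in place of the fluorine, or a longer chain carrying the amine, would hold the number at this place.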